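This account rests on a few compounds, and the source may have more. Where it says the series, first, only, none or still open, it means among the compounds named here.

Within the data shown here, compound 1 `O=S(=O)(Nc1ccc(-c2nc3ccccc3o2)cc1)c1ccc(Cl)s1` gives 31000 nM in an assay on cells for inhibition of HSP60/HSP10 (Homo sapiens), with a stated time of 60 min (on this read-out higher numbers stand for weaker inhibition and lower numbers for stronger inhibition), and is the only compound here with a number rather than a limit. Compound 2 `COc1ccc(Cl)cc1S(=O)(=O)Nc1ccc2oc(-c3ccccc3)nc2c1` returns only a limit, > 100000 nM, in this assay. That limit, (the limit of > 100000 nM in this assay, at which 1 of the 2 values shown sits), is all compound 2 contributes. Compound 3 `Cc1cccc(S(=O)(=O)Nc2ccc(-c3nc4ccccc4o3)cc2)c1` is not yet measured; it differs from compound 1 by 3-methylphenyl in place of 5-chlorothiophen-2-yl on a sulfonyl sulfur. Among the measured compounds shown here, no measured pair carries this change, so its size is unknown. The step from compound 1 to compound 3 is expected to be small, a 1.3-fold higher number from compound 1 to compound 3 (0.11 log units; within the scatter), not clearly beyond the scatter in either direction. Compound 3 is estimated at 40000 nM, with a range from 12000 nM to 130000 nM.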

Compound 3, half-maximal inhibitory concentration: > 100000 nM
Compound 3 was reported as a limit (the forecaster's own chance of this, stated with the estimate: 30%); middle value at least 2.5-fold (0.39 log units) away from the limit.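

On the sulfonyl sulfur, 3-methylphenyl in place of 5-chlorothiophen-2-yl gives an at least 3.2-fold higher number from compound 1 to compound 3 (0.50 log units; beyond the scatter) in this assay, so the group at this position does affect the read-out. Among these compounds, the value of compound 3 is a limit, so this step has a minimum size and no exact size: the limit of > 100000 nM in this assay, at which 2 of the 3 values shown sit. Compound 1 remains the only compound with a number. Whether the chlorine or the thiophene ring accounts for the step stays open. Going by these compounds, the effect of an amine or a carboxylic acid on the sulfonyl sulfur's aromatic ring also remains open.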